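The source may hold more compounds than are shown below. What is called first, only, known or untested is meant among the compounds shown, and "the series" means these compounds.

In a functional assay on HCT-116 cells (Homo sapiens) for inhibition, read by sulforhodamine B assay, with a stated time of 48 h, tested at 50 uM (a higher number here means more inhibition of growth at the concentration tested, a lower number less inhibition of growth), compound 2 `COc1ccc(/C=C/C(=O)/C=C/c2ccc(OCc3cn(CCCOc4cc(=O)oc5ccccc45)nn3)c(OC)c2)cc1OC` gives 67% and compound 1 `COc1cc(/C=C/C(=O)/C=C/c2cccc3ccccc23)ccc1OCc1cn(CCCOc2cc(=O)oc3ccccc23)nn1` gives 66%, so the two stand level within the scatter. Compound 3 `COc1cc(/C=C/C(=O)/C=C/c2ccccc2)ccc1OCc1cn(CCCOc2cc(=O)oc3ccccc23)nn1` keeps the rest of compound 2 and alters one group: phenyl in place of 3,4-dimethoxyphenyl on a double-bonded chain carbon bound to a double-bonded chain carbon. Among the compounds with values here, only one measured step bears on this place, the exchange of naphthalen-1-yl for 3,4-dimethoxyphenyl, which gave a number 1 percentage points higher from compound 1 to compound 2 (within the scatter). Within the data shown here, that single step suggests little sensitivity to the group here, though no measured compound yet carries plain phenyl. The expected change is a number 2 percentage points lower from compound 2 to compound 3 (within the scatter), with no step beyond the scatter anticipated. For compound 3 the estimate is 65%, with an expected range of 52% to 76%.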

Compound 3, percent growth inhibition at one concentration: 45%
Compound 3: the middle estimate sits 20 percentage points above what was measured, outside the stated range (below it).
By their numbers in this assay, from the lowest: compound 3; then compounds 1 and 2 (each within the scatter of the next).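

Replacing either larger group with plain phenyl gives a number 22 percentage points lower from compound 2 to compound 3 (beyond the scatter) and a number 21 percentage points lower from compound 1 to compound 3 (beyond the scatter) in this assay at this position on a double-bonded chain carbon. The level pair of compound 1 and compound 2 therefore did not mean the position was insensitive: 3,4-dimethoxyphenyl and naphthalen-1-yl match each other, but phenyl does not match either. Nothing measured here explains the drop. The compounds shown leave open whether an amine or a chlorine on the phenyl ring would bring the number back up.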